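Hydroxymethyl in Two Related Pairs and Its Effect on Lipophilicity

The source may report more compounds than this note shows. Statements on the series, on what has been measured and on what is new or still open speak of the compounds shown alone.

The account begins with compound 1, `COc1ccc(O)c(CSc2ccccc2)c1`, and compound 2, `COc1ccc(O)c(CSc2ccccc2CO)c1`, which differ in one place only: hydroxymethyl in place of hydrogen on an aromatic carbon. In a physicochemical assay for lipophilicity (a lower number here means a more polar compound, a higher number a more lipophilic compound), compound 1 gives 3.9, and compound 2 gives 2.9, so the step is a number 1.00 log units lower from compound 1 to compound 2 (beyond the scatter).

Compound 3, `Oc1cc2ccoc2cc1CNc1ccccc1`, is built on another core; how its core differs from that of compound 1 is not broken down here. In this assay compound 3 gives 3.3, a number that lies below that of compound 1 and above that of compound 2.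

Compound 4, `OCc1ccccc1NCc1cc2occc2cc1O`, has not been measured. Among the measured compounds shown here, it differs from compound 3 by hydroxymethyl in place of hydrogen on an aromatic carbon, the same change as the one between compound 1 and compound 2, at a place described in the same words. The step is expected to be of much the same size, a number 1.00 log units lower from compound 3 to compound 4 (beyond the scatter), resting on the earlier step of a number 1.00 log units lower from compound 1 to compound 2 (beyond the scatter). Compound 4 is accordingly estimated to give 2.3 in this assay, most likely between 1.8 and 2.8.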

Compound 4, partition coefficient: 2.2
The estimate for compound 4 lay 0.10 log units above the measured number; the range from low to high includes it.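

In this assay, hydroxymethyl in place of hydrogen on an aromatic carbon gives a number 1.10 log units lower from compound 3 to compound 4 (beyond the scatter), and the same change on the core of compound 1 gives a number 1.00 log units lower from compound 1 to compound 2 (beyond the scatter), so in these two pairs the change carries from one core to the other in the same direction and at a closely similar size. Among the compounds shown here, this rests on only two pairs, so it does not show that the step would hold on any other core. The account holds no measurement that bears on why the step takes this size.

The compounds shown leave open whether a different group on the same aromatic carbon, such as an amine, a carboxylic acid or a longer chain like hydroxyethyl, would also carry from one core to the other. They also leave open whether hydroxymethyl would give a similar step at another place on that ring.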